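Replacing 3,4,5-trimethoxyphenyl with 4-methylphenyl in compound 4

This account rests on a few compounds, and the source may have more. Where it says the series, first, only, none or still open, it means among the compounds named here.

Values in an ADME assay on cells (Peritoneal macrophage, Mus musculus, strain Balb/c) for cytotoxicity, read by resazurin assay, with a stated time of 72 h; on this read-out higher numbers stand for lower toxicity in this test and lower numbers for higher toxicity in this test:
Compound 1 `CC1(Cc2cccc([N+](=O)[O-])c2)CC(S(=O)(=O)c2ccc(F)cc2)=C(c2ccc(/C(N)=N/O)cc2)O1`: 86600 nM
Compound 2 `COc1ccc(CC2(C)CC(S(=O)(=O)c3ccc(F)cc3)=C(c3ccc(/C(N)=N/O)cc3)O2)cc1`: > 100000 nM, a limit of the assay
Compound 3 `COc1cc(CC2(C)CC(S(=O)(=O)c3ccc(F)cc3)=C(c3ccc(/C(N)=N/O)cc3)O2)cc(OC)c1OC`: 92300 nM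

In this assay compound 3 stands at 92300 nM, and the nearest number is that of compound 1. Compound 2 gives no number, only (the limit of > 100000 nM in this assay, at which 1 of the 3 values shown sits).

Compound 4 `Cc1ccc(CC2(C)CC(S(=O)(=O)c3ccc(F)cc3)=C(c3ccc(/C(N)=N/O)cc3)O2)cc1` differs from compound 3 by one change: 4-methylphenyl in place of 3,4,5-trimethoxyphenyl on a saturated chain carbon bound to a saturated ring carbon.

Going by the values given here, three measured steps concern the same place: a 1.1-fold higher number from compound 1 to compound 3 (0.03 log units; within the scatter), an at least 1.1-fold higher number from compound 1 to compound 2 (0.06 log units; that floor lies within the scatter) and an at least 1.0-fold lower number from compound 2 to compound 3 (0.03 log units; that floor lies within the scatter). From the compounds shown here alone, the last two are only floors, so their true size remains open. None of the three goes beyond the scatter, and none of them tests a 4-methylphenyl group directly. No step beyond the scatter is therefore expected in this assay. The estimated step is a 1.0-fold higher number from compound 3 to compound 4 (0.01 log units; within the scatter). The assay may also return only a limit for this compound, as it did once before. For compound 4 the expected value is 95000 nM, with an estimated range from 55000 nM to 165000 nM.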

Compound 4, half-maximal cytotoxic concentration: 54400 nM
Compound 4: the middle estimate sits 1.7-fold (0.24 log units) above what was measured; measured number outside the range, below it.
By their numbers in this assay, from the lowest: compounds 4, 1 and 3 (each within the scatter of the next). At a limit, above all of these: compound 2.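

Among the compounds shown, only compound 4 carries a group of carbon only on this saturated chain carbon, and in this assay that change stays within the scatter, both as a 1.7-fold lower number from compound 3 to compound 4 (0.23 log units; within the scatter) and as a 1.6-fold lower number from compound 1 to compound 4 (0.20 log units; within the scatter). From the compounds shown here alone, the exchange of methoxy for methyl on an aromatic carbon can be read only as a floor, an at least 1.8-fold lower number from compound 2 to compound 4 (0.26 log units; that floor lies within the scatter), and its true size remains unknown. Compound 2 gives a limit and not a number: the limit of > 100000 nM in this assay, at which 1 of the 4 values shown sits.

Going by these compounds, it remains open whether an amine or a carboxylic acid on the aromatic ring would give a step beyond the scatter in this assay. A longer chain between this ring and the saturated ring carbon also remains untested among the compounds shown here.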